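A few compounds are considered here, and "the series" means these few. Any claim that something is new, unique, unknown or untested is made for them only; others in the source may bear on it.

Measured so far in a functional assay on K562 cells (Homo sapiens) for cytotoxicity, read by MTT assay, with a stated time of 72 h; a lower number here means that less compound is tolerated, a higher number that more compound is tolerated:

Compound 1, `CS/C(=N\C(=O)c1ccno1)NC(=O)c1ccno1` — in this assay compound 1 gives > 100000 nM, which is a limit of the assay rather than a number.
Compound 2, `O=C(/N=C(/NC(=O)c1ccno1)[Se]Cc1ccccc1)c1ccno1` — in this assay compound 2 gives 94700 nM.
Compound 3, `O=C(/N=C(/NC(=O)c1cccs1)[Se]Cc1ccccc1)c1cccs1` — in this assay compound 3 gives 87400 nM.

Compounds 1 and 2 share a core and differ in one place: a group of 2 heavy atoms (1 carbon, 1 sulfur; no ring) in place of a group of 8 heavy atoms (7 carbon, 1 selenium; one six-membered aromatic ring of carbon only), on a carbon with a double bond to nitrogen. That change gives an at least 1.0-fold higher number from compound 2 to compound 1 (0.02 log units; that floor lies within the scatter), a step that is bounded by the limit of > 100000 nM in this assay, at which 1 of the 3 values shown sits. Compounds 2 and 3 have different cores, and the difference between the two cores is not broken down here; their values in this assay lie within the usual scatter of each other.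

Compound 4, `CS/C(=N\C(=O)c1cccs1)NC(=O)c1cccs1`, has not yet been measured in this assay. It stands to compound 3 as compound 1 stands to compound 2: a group of 2 heavy atoms (1 carbon, 1 sulfur; no ring) in place of a group of 8 heavy atoms (7 carbon, 1 selenium; one six-membered aromatic ring of carbon only), on a carbon with a double bond to nitrogen. Since the place of the change is the same in both pairs, this is the same change. On the core of compound 3, the step is expected to be a 1.4-fold higher number from compound 3 to compound 4 (0.14 log units; within the scatter), resting on the measured step from compound 2 to compound 1 and on compound 3 giving 87400 nM. The value of compound 4 is therefore estimated at 120000 nM, expected to fall between 60000 nM and 250000 nM, with a fair chance that this assay reports only a limit.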

Compound 4, concentration lethal to 50% of the cells: > 100000 nM
Compound 4: no number, only a limit; the forecaster's own chance of this, stated with the estimate: 55%; the middle value does not contradict the limit.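

Compound 4 gives > 100000 nM in this assay, which is a limit of the assay and not a number. Putting methylsulfanyl in place of the selenium-containing group gives an at least 1.1-fold higher number from compound 3 to compound 4 (0.05 log units; that floor lies within the scatter), so the result on the core of compound 3 does not contradict the earlier result, and the two steps can be set side by side: the same change on two cores in this assay, an at least 1.0-fold higher number (0.02 log units; that floor lies within the scatter) from compound 2 to compound 1 and an at least 1.1-fold higher number (0.05 log units; that floor lies within the scatter) from compound 3 to compound 4; the limit leaves it open whether they differ Carrying the change from one core to the other is therefore not contradicted, but it is not shown to have the same size, or any real size at all, since the comparison stops at the assay's ceiling: the limit of > 100000 nM in this assay, at which 2 of the 4 values shown sit.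

The compounds shown leave open what true values compounds 1 and 4 would give, so whether the change matters on either core remains unsettled. They also leave open what an amine or a longer chain, such as ethylsulfanyl, would give at this same place, on a carbon with a double bond to nitrogen.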